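Side chain: cyclohexyl exchanged for tetrahydronaphthalenyl

A few compounds are considered here, and "the series" means these few. Any claim that something is new, unique, unknown or untested is made for them only; others in the source may bear on it.

Measured compounds in an assay on isolated protein for inhibition of cathepsin S (Homo sapiens); on this read-out higher numbers stand for weaker inhibition and lower numbers for stronger inhibition:
Compound 1 `N#C[C@@]1(NC(=O)[C@@H](CC(=O)N2CCOCC2)CC2CCC(c3ccccc3)CC2)CCN(C2CCCCC2)C1`: compound 1 gives 3140 nM.
Compound 2 `CC1CCC(C[C@H](CC(=O)N2CCOCC2)C(=O)N[C@]2(C#N)CCN(C3CCCCC3)C2)CC1`: compound 2 gives 14 nM.
Compound 3 `N#C[C@@]1(NC(=O)[C@@H](CC(=O)N2CCOCC2)CC2CCCCC2)CCN(C2CCCCC2)C1`: compound 3 gives 23 nM.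

Compound 3 holds the second highest of the three numbers. Its nearest neighbour is compound 2, a step within the scatter: a 1.6-fold higher number from compound 2 to compound 3 (0.22 log units; within the scatter). Compound 1 lies far away: a 140-fold lower number from compound 1 to compound 3 (2.14 log units; beyond the scatter).

The next compound is compound 4 `N#C[C@@]1(NC(=O)[C@@H](CC(=O)N2CCOCC2)CC2CCc3ccccc3C2)CCN(C2CCCCC2)C1`. Against compound 3 the change is 1,2,3,4-tetrahydronaphthalen-2-yl in place of cyclohexyl on a saturated chain carbon, two bonds along the chain from a carbonyl carbon.

Going by the values given here, two measured steps touch the same saturated ring. A phenyl on that ring costs a great deal, seen in a 220-fold lower number from compound 1 to compound 2 (2.35 log units; beyond the scatter) and a 140-fold lower number from compound 1 to compound 3 (2.14 log units; beyond the scatter). A methyl in place of hydrogen changes nothing beyond the scatter, seen in a 1.6-fold higher number from compound 2 to compound 3 (0.22 log units; within the scatter). Among the compounds with values here, compound 4 carries neither of these; the fused aromatic ring has no measured counterpart in this set, so the direction is read only by analogy to the phenyl-bearing compound 1, with the fused arrangement taken as a smaller burden than a pendant phenyl.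

The expected step in this assay is a 3.5-fold higher number from compound 3 to compound 4 (0.54 log units; beyond the scatter), toward a higher number. Compound 4 is therefore estimated at 80 nM, with a range from 15 nM to 500 nM.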

Compound 4, half-maximal inhibitory concentration: 1.9 nM
Beside the measured number, compound 4's estimate is 42-fold (1.62 log units) above it, outside the stated range (below it).
By their numbers in this assay, from the lowest: compound 4; then compounds 2 and 3 (each within the scatter of the next); then compound 1.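

In this assay, the saturated chain carbon two bonds along the chain from a carbonyl carbon accepts a larger, partly aromatic group: 1,2,3,4-tetrahydronaphthalen-2-yl in place of cyclohexyl gives a 12-fold lower number from compound 3 to compound 4 (1.08 log units; beyond the scatter) and in place of 4-methylcyclohexyl gives a 7.4-fold lower number from compound 2 to compound 4 (0.87 log units; beyond the scatter) as the step from the methyl-bearing side chain. An aromatic ring in this side chain therefore carries no loss in itself, since compound 1 and compound 4 each hold one and yet 1,2,3,4-tetrahydronaphthalen-2-yl in place of 4-phenylcyclohexyl gives a 1700-fold lower number from compound 1 to compound 4 (3.22 log units; beyond the scatter) in the same read-out, so the way the ring is attached matters far more than its presence. No measurement on hand speaks to the reason for these steps.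

Open, from the compounds shown here alone, is whether the gain needs the six-membered saturated ring of compound 4, which an indan-2-yl or a plain phenyl on the same chain carbon would test. Also open, going by these compounds, is how far the aromatic ring tolerates substitution or replacement, for example by a fluorine, a methoxy group or a pyridine ring.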